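Working notes: chloro to bromo on the shared core

The compounds below may be only part of what the source reports. "The series", "measured", "known", "first", "only" and "open" are said of these compounds alone.

Compound 1 `O=C1C(=O)N(CCCCn2cc(COc3cc(=O)oc4ccccc34)nn2)c2ccc(Br)cc21` gives 56%
Compound 2 `O=C1C(=O)N(CCCCCn2cc(COc3cc(=O)oc4ccccc34)nn2)c2ccc(Cl)cc21` gives 48%
Compound 3 `O=C1C(=O)N(CCCCCn2cc(COc3cc(=O)oc4ccccc34)nn2)c2ccc(Br)cc21` is not yet measured

All values come from a functional assay on COLO 205 cells (Homo sapiens) for inhibition, read by sulforhodamine B assay, with a stated time of 48 h, tested at 50 uM; a higher number here means more inhibition of growth at the concentration tested, a lower number less inhibition of growth. Among the measured compounds shown here, only two numbers exist so far. In this read-out, compound 2 gives 48% and compound 1 gives 56%. These two values lie within the scatter of each other, so the data do not separate the two compounds. For the measured compounds named here, no measured pair differing in one place is available, so the size of a halogen step has not been observed directly.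

Compound 3 carries bromo in place of chloro on an aromatic carbon of the shared core, and otherwise matches compound 2: bromo in place of chloro on an aromatic carbon. In this assay, no step beyond the scatter is expected. The only support is indirect: compound 1 also carries bromo and gives 56%, within the scatter of the value for compound 2. The expected step of a number 4 percentage points higher from compound 2 to compound 3 (within the scatter) is therefore small. For compound 3 the estimated value is 52%, with an expected range of 40% to 64%.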

Compound 3, percent growth inhibition at one concentration: 39%
The estimate for compound 3 lay 13 percentage points above the measured number, and the stated range ends above it.
By their numbers in this assay, from the lowest: compounds 3, 2 and 1 (each within the scatter of the next, the first and the last beyond it).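

In this assay, the first halogen exchange seen directly on the shared core is bromo in place of chloro on an aromatic carbon, meta to a fused ring and para to a fused ring, and it gives a number 9 percentage points lower from compound 2 to compound 3 (within the scatter). This single pair does not separate chloro from bromo at this position, so the halogen exchange alone shows no effect that can be told from the scatter, while the two bromo compounds, which differ only in the chain, do stand apart: compound 1 gives 56% and compound 3 gives 39%, a gap beyond the scatter. Nothing available offers an explanation for either observation.

On these data alone, whether fluoro, methoxy or nitro on the same aromatic carbon would give a number beyond the scatter of the chloro and bromo values remains open. Also open, as far as these compounds go, are whether the gap between the two bromo compounds continues with a longer chain and whether the same chain change carries a comparable gap in the chloro compounds.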